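A few compounds are considered here, and "the series" means these few. Any claim that something is new, unique, unknown or untested is made for them only; others in the source may bear on it.

Of the compounds shown here, three have already been measured in a functional assay on HL-60 cells (Homo sapiens) for cytotoxicity, read by MTT assay, with a stated time of 4 days (a higher number here means a weaker inhibitor, a lower number a stronger inhibitor), and a fourth awaits measurement. Compound 1 `Cc1ccc(-c2cn(C[C@H]3c4c(ccc(O)c4C)[C@@H]4CC[C@@]5(C)C[C@]43CC5=O)nn2)cc1` and compound 2 `C=C1C(=O)[C@]23C[C@@]1(O)CC[C@H]2c1ccc(O)c(C)c1[C@@H]3Cn1cc(-c2ccc(OC)cc2)nn1` are built on related but distinct cores; the difference between the two cores is not broken down here. In this assay, going by the values given here, compound 2 gives 1150 nM, and this is the only actual number among the measured values. For compound 1 this assay reports only a limit, > 20000 nM. Compound 3 `Cc1ccc(-c2cn(C[C@H]3c4c(ccc(OS(=O)(=O)c5ccc(C)cc5)c4C)[C@@H]4CC[C@@]5(C)C[C@]43CC5=O)nn2)cc1` arises from compound 1 by (4-methylphenyl)sulfonyl in place of hydrogen on an oxygen on an aromatic ring. For compound 3 this assay again reports only a limit, > 20000 nM. Because both ends sit at the limit of > 20000 nM in this assay, at which 2 of the 3 values shown sit, the step that the two limits leave unreadable from compound 1 to compound 3 cannot be read in either direction or in size.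

Compound 4 `C=C1C(=O)[C@]23C[C@@]1(O)CC[C@H]2c1ccc(OS(=O)(=O)c2ccc(C)cc2)c(C)c1[C@@H]3Cn1cc(-c2ccc(OC)cc2)nn1` is the compound not yet measured. It arises from compound 2 by (4-methylphenyl)sulfonyl in place of hydrogen on an oxygen on an aromatic ring, which is the same change as that made from compound 1 to compound 3, at the same place. Since the earlier instance of this change left no readable step, it offers no guide to the size of the step from compound 2 to compound 4. The expectation therefore rests on compound 2 alone, whose value of 1150 nM is the starting point. For compound 4 the step expected from the change is a 3.5-fold higher number from compound 2 to compound 4 (0.54 log units; beyond the scatter), with wide uncertainty in both directions. Compound 4 is estimated at 4000 nM in this assay, and is expected to fall between 800 nM and 20000 nM.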

Compound 4, half-maximal inhibitory concentration: 1020 nM
Estimate against measurement, compound 4: 3.9-fold (0.59 log units) above, and the stated range covers the measured number.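

In this assay, replacing hydrogen with (4-methylphenyl)sulfonyl on the oxygen on the aromatic ring gives a 1.1-fold lower number from compound 2 to compound 4 (0.05 log units; within the scatter), so on the core of compound 2 this change, hydroxy to ((4-methylphenyl)sulfonyl)oxy, leaves a difference no larger than repeated measurements would normally produce. The same change on the core of compound 1 gives no readable step, because compound 1 and compound 3 each carry a limit of the assay rather than an actual number: the limit of > 20000 nM in this assay, at which 2 of the 4 values shown sit. The series therefore offers one readable instance of this change, which shows what happens on one core but cannot show whether the result carries over to the other, so the two cores can be neither matched nor contrasted for this change.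

The compounds shown leave open whether the free hydroxy matters at all on the core of compound 2, or whether a quite different group on the same oxygen, such as acetyl, a longer alkyl chain or a chain ending in an amine, would also leave the reading in this assay unmoved. They also leave open how the core of compound 1 responds to any such change, since neither of its two compounds gives an actual number.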